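From 4-methylbenzyl to 4-chlorobenzyl: what to expect

The compounds below may be only part of what the source reports. "The series", "measured", "known", "first", "only" and "open" are said of these compounds alone.

Measured in a functional assay on G55T2 cells (Homo sapiens) for antiproliferative activity, read by WST assay, with a stated time of 72 h; a lower number here means a stronger inhibitor, a higher number a weaker inhibitor:
compound 1 `Cc1ccc(NC(=O)CCN(Cc2ccc(C(=O)NO)cc2)C(=O)c2cc(C)cc(C)c2)cc1`: 370 nM
compound 2 `Cc1ccc(CNC(=O)CCN(Cc2ccc(C(=O)NO)cc2)C(=O)c2ccc(N(C)C)cc2)cc1`: 430 nM
compound 3 `Cc1ccc(NC(=O)CCN(Cc2ccc(C(=O)NO)cc2)C(=O)c2ccccc2)cc1`: 540 nM

All three values lie within the scatter of one another, so compound 2, at 430 nM, stands level with compound 1 and compound 3. Compound 4 `CN(C)c1ccc(C(=O)N(CCC(=O)NCc2ccc(Cl)cc2)Cc2ccc(C(=O)NO)cc2)cc1` differs from compound 2 by one change, chloro in place of methyl on an aromatic carbon, which turns 4-methylbenzyl into 4-chlorobenzyl. Within the data shown here, no measured step covers this place. Among the measured compounds shown here, the only measured step, a 1.5-fold higher number from compound 1 to compound 3 (0.16 log units; within the scatter), concerns a different group and stays within the scatter, so it suggests no real shift here. The step of a 1.1-fold lower number from compound 2 to compound 4 (0.03 log units; within the scatter) is therefore expected to stay within the scatter, with no firm direction. In this assay compound 4 is estimated at 400 nM, with an expected range from 200 nM to 800 nM.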

Compound 4, half-maximal inhibitory concentration: 460 nM
For compound 4 the middle estimate is 1.2-fold (0.06 log units) below the measured one; the range from low to high includes it.
By their numbers in this assay, from the lowest: compounds 1, 2, 4 and 3 (each within the scatter of the next).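

In this assay, among these compounds, the first measured step at this place, an aromatic carbon para to a large group, is a 1.1-fold higher number from compound 2 to compound 4 (0.03 log units; within the scatter). Methyl and chloro here therefore give numbers level with each other, and the 4-chlorobenzyl group serves as well as the 4-methylbenzyl group. Nothing available explains this outcome. The compounds shown leave open whether a methoxy group or a carboxylic acid at this place would give a step beyond the scatter. They also leave open whether chloro for methyl reads the same without the dimethylamino group elsewhere in the molecule.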